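Pyrazole carboxylic acid series: carboxy to hydroxymethyl step

A few compounds are considered here, and "the series" means these few. Any claim that something is new, unique, unknown or untested is made for them only; others in the source may bear on it.

Measured compounds in a functional assay on Maver1 cells (Homo sapiens) for inhibition, read by luminescence and CellTiter-Glo, with a stated time of 72 h; on this read-out lower numbers stand for stronger inhibition and higher numbers for weaker inhibition:
compound 1 `O=C(CCl)Nc1ccc(Cn2nc(-c3ccc(Oc4ccccc4)cc3)cc2C(=O)O)cc1`, compound 1 gives 1200 nM
compound 2 `C=CC(=O)Nc1cccc(Cn2nc(-c3ccc(Oc4ccccc4)cc3)cc2C(=O)O)c1`, compound 2 gives 37400 nM
compound 3 `O=C(CCl)Nc1cccc(Cn2nc(-c3ccc(Oc4ccccc4)cc3)cc2C(=O)O)c1`, compound 3 gives 4700 nM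

Compound 1 stands at the lowest number of the three. Its nearest neighbour is compound 3, with a 3.9-fold higher number from compound 1 to compound 3 (0.59 log units; beyond the scatter); the furthest is compound 2, with a 31-fold higher number from compound 1 to compound 2 (1.49 log units; beyond the scatter). Between the other two, an 8.0-fold lower number from compound 2 to compound 3 (0.90 log units; beyond the scatter). All three measured steps concern the amide on the benzylic aryl ring: where it sits and whether it is a chloromethyl or a vinyl carbonyl. None of them touches the carboxy on the shared core.

Compound 4 `O=C(CCl)Nc1ccc(Cn2nc(-c3ccc(Oc4ccccc4)cc3)cc2CO)cc1` differs from compound 1 by hydroxymethyl in place of carboxy on an aromatic carbon. Going by the values given here, no measured step bears on this change, so the direction and size of the step in this assay cannot be read from the data in hand. The estimate for compound 4 is therefore wide, centred on a weaker number than compound 1 but with a range that reaches back to the value of compound 1 itself. Compound 4 is expected at 5000 nM, within 1200 nM to 25000 nM, which amounts to an expected 4.2-fold higher number from compound 1 to compound 4 (0.62 log units; beyond the scatter).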

Compound 4, half-maximal inhibitory concentration: 400 nM
Estimate against measurement, compound 4: 13-fold (1.10 log units) above; the whole stated range lies above it.
By their numbers in this assay, from the lowest: compound 4; then compound 1; then compound 3; then compound 2.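

In this assay, the carboxy on the shared core proves dispensable for inhibition in this pair: with the 4-(((chloromethyl)carbonyl)amino)phenyl group held fixed, hydroxymethyl in place of carboxy gives a 3.0-fold lower number from compound 1 to compound 4 (0.48 log units; beyond the scatter). Going by these compounds alone, this is the only measured step at this aromatic carbon, next to the ring nitrogen, and it shows that this position also moves the number, whereas the earlier steps spoke only to the amide on the benzylic aryl ring. The swap removes one oxygen and the double bond outside aromatic rings while the counted hydrogen-bond donors and acceptors stay the same, and nothing measured here explains the direction of the step.

From the compounds shown here alone, the step rests on a single pair, so it remains open whether hydroxymethyl would lower the number in the same way with the 3-(((chloromethyl)carbonyl)amino)phenyl group of compound 3 or the 3-((vinylcarbonyl)amino)phenyl group of compound 2. The compounds shown also leave open how a methyl ester, a primary amide, a methoxymethyl group or a longer hydroxyethyl chain would read at this carbon.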